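Notes on the step from compound 3 to compound 4

The source may hold more compounds than are shown below. What is called first, only, known or untested is meant among the compounds shown, and "the series" means these compounds.

In a functional assay on MCF7 cells (Homo sapiens) for inhibition, read by MTT assay, with a stated time of 72 h (a lower number here means a stronger inhibitor, a higher number a weaker inhibitor), the series reads as follows:
compound 1 `COc1cc(NC(C)CCCNC(=O)Nc2cccc(Cl)c2)c2ncccc2c1` gives 11000 nM
compound 2 `COc1cc(NC(C)CCCNC(=O)Nc2ccc(Br)cc2)c2ncccc2c1` gives 2600 nM
compound 3 `COc1cc(NC(C)CCCNC(=O)NNC(=O)Nc2ccc(Br)cc2)c2ncccc2c1` gives 100 nM

Compound 3 holds the lowest of the three numbers and lies beyond the scatter from both others. The change to compound 4 `COc1cc(NC(C)CCCNC(=O)Nc2ccc(C(F)(F)F)cc2)c2ncccc2c1` is 4-(trifluoromethyl)phenyl in place of ((4-bromophenyl)carbamoyl)amino on an amide-type nitrogen and it removes the carbamoylamino link, leaving a phenyl group on the amide-type nitrogen as in compound 2. Going by the values given here, two measured steps bear on this. The step of a 26-fold lower number from compound 2 to compound 3 (1.41 log units; beyond the scatter) is large and is the closest match, run in reverse. The step of a 4.2-fold lower number from compound 1 to compound 2 (0.63 log units; beyond the scatter) is modest and shows how much a change of phenyl group alone has moved the number. Among the compounds with values here, no measured compound carries trifluoromethyl, so the gap to compound 2 stays open. In this assay a large step to a higher number is therefore expected, close in size to the step of a 26-fold lower number from compound 2 to compound 3 (1.41 log units; beyond the scatter) in the opposite direction. The estimate is a 40-fold higher number from compound 3 to compound 4 (1.60 log units; beyond the scatter) as an expected step. For compound 4 the estimated value is 4000 nM with an expected range from 1500 nM to 11000 nM for now.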

Compound 4, half-maximal inhibitory concentration: 1900 nM
Compound 4: middle estimate off by 2.1-fold (0.32 log units), on the high side, and the stated range covers the measured number.
By their numbers in this assay, from the lowest: compound 3; then compounds 4 and 2 (each within the scatter of the next); then compound 1.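

In this assay, the step of a 19-fold higher number from compound 3 to compound 4 (1.28 log units; beyond the scatter) shows that 4-(trifluoromethyl)phenyl directly on the amide-type nitrogen, without the carbamoylamino link, stays far from the number of compound 3, as 4-bromophenyl did. The step of a 1.4-fold lower number from compound 2 to compound 4 (0.14 log units; within the scatter) lies within the scatter, so trifluoromethyl and bromo on the aromatic carbon cannot be told apart here, and the large steps in this series go with the link and not with this exchange. The step of a 5.8-fold lower number from compound 1 to compound 4 (0.76 log units; beyond the scatter) is modest and places compound 4 on the same side of compound 1 as compound 2.

As far as these compounds go, whether the link keeps its large step with trifluoromethyl in place of bromo, and how a nitrile or an amine on the phenyl ring or a longer chain in the link would read, stays open. Nothing available here gives a reason for these steps.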